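This account rests on a few compounds, and the source may have more. Where it says the series, first, only, none or still open, it means among the compounds named here.

Working notes on the series. In an in vivo functional assay on the whole organism for inhibition, with Rattus norvegicus as the target (on this read-out lower numbers stand for an effect already at smaller amounts and higher numbers for an effect only at larger amounts of compound), compound 1 `CCCCc1nc(C)c(CC(=O)N2CCC[C@H]2C(=O)OC)c(=O)n1Cc1ccc(-c2ccccc2-c2nnn[nH]2)cc1` gives 0.043 mg/kg, compound 2 `CCCCc1nc(C)c(CCC(=O)N2CCSCC2)c(=O)n1Cc1ccc(-c2ccccc2-c2nnn[nH]2)cc1` gives 0.204 mg/kg, and compound 3 `CCCCc1nc(C)c(CCC(=O)N2CCCC2)c(=O)n1Cc1ccc(-c2ccccc2-c2nnn[nH]2)cc1` gives 0.206 mg/kg. Compound 3 therefore sits with compound 2 at the high end of these three numbers, and both lie clearly above compound 1.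

The next structure is compound 4 `CCCCc1nc(C)c(CC(=S)N2CCCCCC2)c(=O)n1Cc1ccc(-c2ccccc2-c2nnn[nH]2)cc1`. The change is a group of 9 heavy atoms (7 carbon, 1 nitrogen, 1 sulfur; one seven-membered non-aromatic ring with 1 hetero atom) in place of a group of 8 heavy atoms (6 carbon, 1 nitrogen, 1 oxygen; one five-membered non-aromatic ring with 1 hetero atom), on a saturated chain carbon bound to an aromatic carbon, so a seven-membered non-aromatic ring enters and a five-membered one leaves.

The closest evidence is the ring exchange on the carbonyl carbon, a 1.0-fold higher number from compound 2 to compound 3 (0.00 log units; within the scatter), which stays within the scatter. The two larger measured changes are modest: a 4.7-fold higher number from compound 1 to compound 2 (0.68 log units; beyond the scatter) and a 4.8-fold higher number from compound 1 to compound 3 (0.68 log units; beyond the scatter). For the measured compounds named here, no measured compound carries the entering group, so these steps offer only a rough guide to size. No step beyond the scatter is expected in this assay, and neither direction is favoured.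

The expected result is a 1.0-fold lower number from compound 3 to compound 4 (0.01 log units; within the scatter). Compound 4 is estimated at 0.2 mg/kg, with an expected range of 0.05 mg/kg to 0.8 mg/kg.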

Compound 4, dose for half-maximal effect: 0.034 mg/kg
Compound 4: the middle estimate sits 5.9-fold (0.77 log units) above what was measured, and the stated range ends above it.
By their numbers in this assay, from the lowest: compounds 4 and 1 (each within the scatter of the next); then compounds 2 and 3 (each within the scatter of the next).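

The group on this saturated chain carbon bound to an aromatic carbon is not indifferent in this assay: the ring exchange in a 1.0-fold higher number from compound 2 to compound 3 (0.00 log units; within the scatter) left the number in place, whereas the new group gives a 6.1-fold lower number from compound 3 to compound 4 (0.78 log units; beyond the scatter) and a 6.0-fold lower number from compound 2 to compound 4 (0.78 log units; beyond the scatter). The comparison with the ester-bearing compound gives a 1.3-fold lower number from compound 1 to compound 4 (0.10 log units; within the scatter), so among these compounds a number in the low range does not require the methoxycarbonyl group. No measurement on hand accounts for these steps.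

The new group differs from those of compounds 2 and 3 in both its ring and its sulfur, and the compounds shown do not separate these two changes. Open too, going by these compounds, is how a seven-membered ring with a plain carbonyl, a pyrrolidine with a thiocarbonyl, or a carboxylic acid in place of the methoxycarbonyl would read.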